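The source may report more compounds than this note shows. Statements on the series, on what has been measured and on what is new or still open speak of the compounds shown alone.

Within the data shown here, in a physicochemical assay for solubility, using the shake flask method, in simulated intestinal fluid, measured as kinetic solubility, with a stated time of 20 h, at pH 6.5 (on this read-out lower numbers stand for lower solubility and higher numbers for higher solubility), compound 2 (`FC1(F)CCC(c2nc3cnc(Nc4ccc(C(F)(F)F)cn4)cc3[nH]2)C1`) gives 163000 nM, the only exact number so far. Compound 1 (`Fc1ccc(-c2nc3cnc(Nc4cc(C(F)(F)F)ccn4)cc3[nH]2)cc1F`) gives >= 50000 nM, which is a limit of the assay and not a number. The two therefore cannot be ranked, and compound 2 stands alone as the starting point for the next comparison.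

Compound 3 (`FC(F)(F)c1ccc(Nc2cc3[nH]c([C@H]4CC[C@H](C(F)(F)F)CC4)nc3cn2)nc1`) keeps the shared core but carries 4-(trifluoromethyl)cyclohexyl in place of 3,3-difluorocyclopentyl on an aromatic carbon. Among the measured compounds shown here, no measured pair of compounds shows what such a swap does, so this expectation rests on the structural change alone. The entering group is the larger one and adds no hydrogen-bond donors or acceptors, so a moderate fall beyond the usual scatter is expected. The estimated change is a 4.1-fold lower number from compound 2 to compound 3 (0.61 log units; beyond the scatter). The expected value for compound 3 is 40000 nM, with an estimated range of 8000 nM to 150000 nM.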

Compound 3, solubility: 104000 nM
For compound 3 the middle estimate is 2.6-fold (0.41 log units) below the measured one; the measured number falls inside the stated range.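

In this assay, putting 4-(trifluoromethyl)cyclohexyl in place of 3,3-difluorocyclopentyl on an aromatic carbon gives a 1.6-fold lower number from compound 2 to compound 3 (0.20 log units; within the scatter), so the two compounds cannot be told apart. Among these compounds, this is the first measured pair that differs in one place, and it shows that a group with more heavy atoms and a six-membered ring can stand at this position without the reading moving beyond the scatter. Compound 1 remains a limit and not a number, and it differs from compound 2 in more than one place, so it adds no step here: the limit of >= 50000 nM in this assay, at which 1 of the 3 values shown sits.

Going by these compounds, both groups compared have no hydrogen-bond donors or acceptors and no net charge, so what an amine or a carboxylic acid on this aromatic carbon would do to the reading remains open. Also open, on these data alone, is whether the other stereoisomer of 4-(trifluoromethyl)cyclohexyl would read the same.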